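Cyanomethyl on the ring amine nitrogen in compound 4

The source may hold more compounds than are shown below. What is called first, only, known or untested is meant among the compounds shown, and "the series" means these compounds.

Values so far in an in vitro ADME assay on microsomes from liver (Mus musculus) for pharmacokinetics, read by LC-MS, with a stated time of 10 min, tested at 1 uM; on this read-out higher numbers stand for fast clearance and lower numbers for slow clearance
- Compound 1 `CCN1C[C@H](C(=O)Nc2ccc(Cl)cc2)[C@@H](c2ccc(/C=C/C(=O)Nc3ccccc3N)cc2)C1` gives 35 mL/min/kg
- Compound 2 `CC(C)N1C[C@H](C(=O)Nc2ccc(Cl)cc2)[C@@H](c2ccc(/C=C/C(=O)Nc3ccccc3N)cc2)C1` gives 38 mL/min/kg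
- Compound 3 `CC(C)(CO)N1C[C@H](C(=O)Nc2ccc(Cl)cc2)[C@@H](c2ccc(/C=C/C(=O)Nc3ccccc3N)cc2)C1` gives 40 mL/min/kg

Compound 3 at 40 mL/min/kg stands level with the other two compounds, as all three lie within the scatter of one another. The change to compound 4 `N#CCN1C[C@H](C(=O)Nc2ccc(Cl)cc2)[C@@H](c2ccc(/C=C/C(=O)Nc3ccccc3N)cc2)C1` is cyanomethyl in place of 1-(hydroxymethyl)-1-methylethyl on an amine nitrogen in a ring with cyanomethyl in place of 1-(hydroxymethyl)-1-methylethyl on an amine nitrogen in a ring. Three measured steps at that nitrogen bear on it, namely a 1.1-fold higher number from compound 1 to compound 2 (0.04 log units; within the scatter) and a 1.1-fold higher number from compound 1 to compound 3 (0.06 log units; within the scatter) and a 1.1-fold higher number from compound 2 to compound 3 (0.02 log units; within the scatter) and all stay within the scatter. None of them brings in cyanomethyl, so their support is indirect. The expected outcome is a 1.1-fold lower number from compound 3 to compound 4 (0.05 log units; within the scatter) and so no shift beyond the scatter. In this assay compound 4 is estimated at 36 mL/min/kg and expected between 22 mL/min/kg and 58 mL/min/kg on measurement.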

Compound 4, clearance: 51 mL/min/kg
For compound 4 the middle estimate is 1.4-fold (0.15 log units) below the measured one; the measured number falls inside the stated range.
By their numbers in this assay, from the lowest: compounds 1, 2, 3 and 4 (each within the scatter of the next).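

Cyanomethyl on the ring amine nitrogen brings a 1.3-fold higher number from compound 3 to compound 4 (0.11 log units; within the scatter) and a 1.3-fold higher number from compound 2 to compound 4 (0.13 log units; within the scatter) and a 1.5-fold higher number from compound 1 to compound 4 (0.16 log units; within the scatter) in this assay and so stays level with all three earlier groups. The earlier compounds shown here carried only saturated chains at this nitrogen, and this step shows that a group ending in a nitrile also leaves the read-out within the scatter.

On these data alone, whether a carboxylic acid, an amide or a cyclopropyl ring on this nitrogen would move clearance beyond the scatter stays open. Nothing measured here offers an explanation for these numbers.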